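Adding a Cyclopropyl Branch to a Fatty Acid Receptor Agonist

This account rests on a few compounds, and the source may have more. Where it says the series, first, only, none or still open, it means among the compounds named here.

compound 1, `CC#CC(CC(=O)O)c1ccc(OCc2ccc(C(=O)N3CCN(C)CC3)s2)cc1`: > 5000 nM
compound 2, `O=C(O)CCc1ccc(OCc2ccc(C(=O)N3CCN(c4ccc(F)cc4)CC3)s2)cc1`: 610 nM

Of the compounds shown here, two have been measured in a functional assay on HEK293 cells for agonist activity at Free fatty acid receptor 1 (Homo sapiens), read by fluorescence and calcium flux; a lower number here means that less compound is needed, a higher number that more compound is needed for the effect. Compound 1, `CC#CC(CC(=O)O)c1ccc(OCc2ccc(C(=O)N3CCN(C)CC3)s2)cc1`, returns only a limit in this assay, > 5000 nM, as noted in the limit of > 5000 nM in this assay, at which 1 of the 2 values shown sits. For the measured compounds named here, compound 2, `O=C(O)CCc1ccc(OCc2ccc(C(=O)N3CCN(c4ccc(F)cc4)CC3)s2)cc1`, gives 610 nM in this assay and is the single full number, so it serves as the reference point. Compound 3, `O=C(O)CC(c1ccc(OCc2ccc(C(=O)N3CCN(c4ccc(F)cc4)CC3)s2)cc1)C1CC1`, differs from compound 2 by cyclopropyl in place of hydrogen on a saturated chain carbon bound to an aromatic carbon and a saturated chain carbon. Going by the values given here, no measured pair shows this change, so its size is open; a modest gain is expected, though a shift either way within scatter would not surprise. Compound 3 is expected to give about 300 nM, within 80 nM to 1500 nM. That expected value corresponds to a step of a 2.0-fold lower number from compound 2 to compound 3 (0.31 log units; beyond the scatter).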

Compound 3, half-maximal effective concentration: > 1660 nM
Compound 3: no number, only a limit (the forecaster's own chance of this, stated with the estimate: 10%); middle value at least 5.5-fold (0.74 log units) away from the limit.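

This is the first one-place comparison at this carbon among the compounds shown, and it shows that cyclopropyl in place of hydrogen here makes the compound weaker, not stronger. In this assay compound 3 returns only a limit, > 1660 nM. As far as these compounds go, the change therefore gives an at least 2.7-fold higher number from compound 2 to compound 3 (0.43 log units; beyond the scatter), and the true size of the loss stays unknown.

The compounds shown leave open whether a smaller group at this carbon, such as methyl or a hydroxyl, would keep the activity of compound 2.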